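Swapping a Benzyloxy Group for a Fluorophenyl Ring

The source may report more compounds than this note shows. Statements on the series, on what has been measured and on what is new or still open speak of the compounds shown alone.

Compound 1 `C=C[C@@](C)(/C=C/c1ccc(OCc2ccccc2)cc1)CCC=C(C)C` was tested in a functional assay on HepG2 cells (Homo sapiens) for cytotoxicity, with a stated time of 72 h; on this read-out higher numbers stand for an effect only at larger amounts of compound and lower numbers for an effect already at smaller amounts. In this assay compound 1 gives only a limit, > 52000 nM, not a number. Compound 2 `C=C[C@@](C)(/C=C/c1ccc(O)cc1)CC/C=C(\C)CO` likewise gives only a limit in this assay, > 52000 nM. Compound 3 `CCOC(=O)/C=C/c1cc(/C=C/[C@](C)(/C=C/c2ccc(OC)cc2)CCC=C(C)C)ccc1O` also reaches only a limit in this assay, > 52000 nM. Thus compound 1 stands where all three measured compounds stand: at the limit of > 52000 nM in this assay, at which 3 of the 3 values shown sit, and no measured compound shows an effect within the tested range.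

Compound 4 `C=C[C@@](C)(/C=C/c1ccc(-c2ccc(F)cc2)cc1)CCC=C(C)C` has not yet been measured in this assay. It differs from compound 1 in one place: 4-fluorophenyl in place of benzyloxy on an aromatic carbon. Among the compounds with values here, no step between measured compounds is available to show what such a change does here, so there is no basis for expecting a shift beyond the scatter in either direction. The step from compound 1 to compound 4 is expected to be small, about a step that the limit leaves unreadable from compound 1 to compound 4. Compound 4 is therefore estimated to show a half-maximal effective concentration of about 60000 nM, within a range from 20000 nM to 200000 nM, most likely again as a limit rather than a number.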

Compound 4, half-maximal effective concentration: > 52000 nM
Compound 4 gave a limit, no number; the forecaster's own chance of this, stated with the estimate: 80%; the middle value does not contradict the limit.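

Within the data shown here, compound 1 and compound 4 both end at a limit rather than a number in this assay, so no step between them can be read: the limit of > 52000 nM in this assay, at which 4 of the 4 values shown sit. The compounds shown leave open whether any change to the shared core brings an effect within the tested range.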